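The source may hold more compounds than are shown below. What is called first, only, known or untested is meant among the compounds shown, and "the series" means these compounds.

Measured compounds in an ADME assay on MCF-10A cells (Homo sapiens) for cytotoxicity, read by MTT assay, with a stated time of 48 h; on this read-out higher numbers stand for weaker inhibition and lower numbers for stronger inhibition:

compound 1, `N#Cc1ccc(OCc2nnc(-c3ccccc3)o2)cc1F`, gives > 100000 nM, which is a limit of the assay and not a number.
compound 2, `COc1ccc(-c2nnc(COc3ccc(C#N)c(F)c3)o2)cc1`, gives > 100000 nM, likewise a limit.
compound 3, `c1ccc(-c2nnc(COc3ccc(-c4nnco4)cc3)o2)cc1`, gives > 100000 nM, likewise a limit.

All three values sit at the same limit, (the limit of > 100000 nM in this assay, at which 3 of the 3 values shown sit), so none of the three is set apart from another by this read-out. The change from compound 1 to compound 2 is methoxy in place of hydrogen on an aromatic carbon. The matching step in this assay is a step that the two limits leave unreadable from compound 1 to compound 2; with both ends at the limit, its size cannot be read. How the core of compound 1 differs from the core of compound 3 is not broken down here.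

Compound 4, `COc1ccc(-c2nnc(COc3ccc(-c4nnco4)cc3)o2)cc1`, has not yet been measured in this assay. It differs from compound 3 by methoxy in place of hydrogen on an aromatic carbon, the same change as that made from compound 1 to compound 2, at a place described in the same words. For the measured compounds named here, the one measured instance of this change left both its compounds at the limit, and compound 3 itself sits at the limit, so the expectation for compound 4 is that this assay again reports only a limit. For compound 4 the step is expected to be a number no higher from compound 3 to compound 4 (the limit leaves the size open). The estimate for compound 4 in this assay is 100000 nM, expected to fall between 50000 nM and 200000 nM, most probably as a limit once more.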

Compound 4, half-maximal inhibitory concentration: > 100000 nM
Compound 4: no number, only a limit; the forecaster's own chance of this, stated with the estimate: 90%; the middle value sits exactly at the limit.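

In this assay compound 4 gives > 100000 nM, a limit of the assay and not a number. Compound 3 and compound 4 therefore stand at the same limit, and no new step can be read between them: the limit of > 100000 nM in this assay, at which 4 of the 4 values shown sit.

The compounds shown leave open whether the methoxy change, or the difference between the cores, alters this read-out at all, and at what concentration any of these compounds would reach half-maximal inhibition.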